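Closing the diethylamino group into a pyrrolidine ring

A few compounds are considered here, and "the series" means these few. Any claim that something is new, unique, unknown or untested is made for them only; others in the source may bear on it.

Compound 1 `CCN(CC)c1ccc(-c2cccc(C(F)(F)F)c2)nn1` gives > 25000 nM (a limit).
Compound 2 `CCOC(=O)c1cccc(-c2ccc(N(CC)CC)nn2)c1` gives > 25000 nM (a limit).

Both results come from a functional assay on PC-3 cells (Homo sapiens) for antiproliferative activity, with a stated time of 48 h; on this read-out higher numbers stand for weaker inhibition and lower numbers for stronger inhibition. In this assay, compound 1 has no exact number, and its result of > 25000 nM is a limit. The evidence so far is short: the limit of > 25000 nM in this assay, at which 2 of the 2 values shown sit.

Compound 3 `FC(F)(F)c1cccc(-c2ccc(N3CCCC3)nn2)c1` carries a new change at the other end of the molecule, with pyrrolidin-1-yl in place of diethylamino on an aromatic carbon. The same two groups are not compared in any measured pair. Going by the values given here, the only measured step, ethoxycarbonyl in place of trifluoromethyl on an aromatic carbon, is a step that the two limits leave unreadable from compound 1 to compound 2. It concerns a different place and gives no size to carry over.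

With no readable size or direction to build on, no shift beyond the usual scatter is expected in this assay, and a further limit is quite likely. The expected step is a number no higher from compound 1 to compound 3 (the limit leaves the size open). Compound 3 is estimated at 25000 nM, with an expected range from 10000 nM to 50000 nM.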

Compound 3, half-maximal inhibitory concentration: > 25000 nM
Compound 3: only a limit was reported; the forecaster's own chance of this, stated with the estimate: 70%; the middle value sits exactly at the limit.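

In this assay, going by these compounds alone, compound 3 gives > 25000 nM, which is a limit, so the step from compound 1 to compound 3 cannot be read, and neither can the one from compound 1 to compound 2. The compounds shown leave open whether either change alters activity at all, and by how much, with only this to go on: the limit of > 25000 nM in this assay, at which 3 of the 3 values shown sit.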